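Aryloxypropyl spirocyclic triazine series: notes toward compound 4

The source may report more compounds than this note shows. Statements on the series, on what has been measured and on what is new or still open speak of the compounds shown alone.

Measured compounds:
- compound 1 `Cc1ccc(OCCCON2C(N)=NC(N)=NC23CCOCC3)cc1`: "not determined" (no result reported)
- compound 2 `CC(C)(C)c1ccc(OCCCON2C(N)=NC(N)=NC23CCSCC3)cc1`: 70 nM
- compound 3 `COc1ccc(OCCCON2C(N)=NC(N)=NC23CCSCC3)cc1`: 880 nM

In a functional assay on HepG2 cells (Homo sapiens) for antiproliferative activity, read by MTT assay, with a stated time of 72 h (on this read-out higher numbers stand for weaker inhibition and lower numbers for stronger inhibition), compound 1 has no number; its result is recorded as "not determined" (no result reported). For the measured compounds named here, compound 2 gives 70 nM and compound 3 gives 880 nM; the only quantified step is a 13-fold higher number from compound 2 to compound 3 (1.10 log units; beyond the scatter), methoxy in place of tert-butyl on an aromatic carbon, on a core that carries sulfur rather than oxygen.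

Compound 4 `Cc1cc(C)cc(OCCCON2C(N)=NC(N)=NC23CCOCC3)c1` differs from compound 1 by 3,5-dimethylphenyl in place of 4-methylphenyl on an oxygen on a saturated carbon. Going by the values given here, no measured step shares this change, and compound 1 itself carries no number, so the expectation rests only on the span set by compound 2 and compound 3. Compound 4 is therefore estimated at 300 nM, within a wide range of 60 nM to 1500 nM.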

Compound 4, half-maximal inhibitory concentration: 680 nM
For compound 4 the middle estimate is 2.3-fold (0.36 log units) below the measured one; the range from low to high includes it.
By their numbers in this assay, from the lowest: compound 2; then compounds 4 and 3 (each within the scatter of the next).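

In this assay, for the compounds shown here, compound 1 is recorded as "not determined" (no result reported) and compound 4 gives 680 nM, so no step between compound 1 and compound 4 can be read. Open remains what 3,5-dimethylphenyl in place of 4-methylphenyl does to the number on their shared core. No evidence at hand bears on this result.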